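A few compounds are considered here, and "the series" means these few. Any claim that something is new, unique, unknown or untested is made for them only; others in the source may bear on it.

Three compounds share one core and differ in the amine attached to the aromatic ring. Compound 1 `OCc1cc(N2CCCC2)ccc1-c1nc2c(s1)C(O)CCC2` carries a pyrrolidin-1-yl group there. Compound 3 `OCc1cc(N2CCCC2)ccc1-c1nc2c(s1)C(O)CNC2` carries the same group on a core whose ring differs from that of compound 1, and compound 2 `CN(C)c1ccc(-c2nc3c(s2)C(O)CNC3)c(CO)c1` carries a dimethylamino group on the core of compound 3. The difference between the two cores is not broken down here.

In a functional assay on HCT-116 cells (Homo sapiens) for cytotoxicity, read by sulforhodamine B assay, with a stated time of 2 days (on this read-out higher numbers stand for weaker inhibition and lower numbers for stronger inhibition), compound 1 gives 42 nM. In this assay compound 3 gives 70 nM, and compound 2 gives 100 nM. Compound 1 and compound 3 lie within the scatter of each other, so no order between them can be read from these numbers; compound 2 stands beyond the scatter from compound 1.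

Going by the values given here, the one change that has been measured directly is dimethylamino in place of pyrrolidin-1-yl on an aromatic carbon, which gave a 1.4-fold higher number from compound 3 to compound 2 (0.15 log units; within the scatter). The same change applied to compound 1 gives compound 4 `CN(C)c1ccc(-c2nc3c(s2)C(O)CCC3)c(CO)c1`, not yet measured: dimethylamino in place of pyrrolidin-1-yl on an aromatic carbon.

Since the change from compound 3 to compound 2 moved the number only within the scatter, a step of similar size is expected from compound 1 to compound 4, a 1.4-fold higher number from compound 1 to compound 4 (0.15 log units; within the scatter), resting on the value of compound 1 at 42 nM and on the step of a 1.4-fold higher number from compound 3 to compound 2 (0.15 log units; within the scatter). Compound 4 is therefore estimated at 60 nM in this assay, with a likely range from 30 nM to 120 nM.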

Compound 4, half-maximal inhibitory concentration: 60 nM
Beside the measured number, compound 4's estimate shows no gap at the digits printed; low and high end bracket the measured number.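

Replacing pyrrolidin-1-yl with dimethylamino on the core of compound 1 gives a 1.4-fold higher number from compound 1 to compound 4 (0.15 log units; within the scatter). Set beside the same replacement on the core of compound 3, the change carries over from one core to the other with no difference that can be told apart in this assay: the same change on two cores in this assay, a 1.4-fold higher number (0.15 log units; within the scatter) from compound 3 to compound 2 and a 1.4-fold higher number (0.15 log units; within the scatter) from compound 1 to compound 4, 1.0-fold (0.00 log units) apart, within the scatter of two such steps

This agreement is between two small steps, both within the scatter, so it shows only that the replacement leaves the number close to where it started on these two cores; it does not show that either amine is better than the other, it does not explain why the two steps match, and two cores are too few to predict the result on a third.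

The compounds shown leave open whether a different group at this place, such as morpholin-4-yl, piperidin-1-yl or a simple unsubstituted amine, would move the number beyond the scatter. They also leave open how the number would respond if the hydroxymethyl group on the same ring gave way to a methyl group or a carboxylic acid.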